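The compounds below may be only part of what the source reports. "The series", "measured", "known", "first", "only" and "open" are said of these compounds alone.

Measured so far:
- compound 1 `CCC(CC)C(=O)Nc1c(C(O)(C(F)(F)F)C(F)(F)F)ccc2ccccc12`: in an assay on LtK cells with ATP-sensitive inward rectifier potassium channel 11 (Homo sapiens) as the target (a higher number here means that more compound is needed for the effect, a lower number that less compound is needed), compound 1 gives 4340 nM
- compound 2 `O=C(Nc1ccc(Cl)cc1)Nc1c(C(O)(C(F)(F)F)C(F)(F)F)ccc2ccccc12`: in this assay compound 2 gives 276 nM
- compound 3 `O=C(Nc1c(C(O)(C(F)(F)F)C(F)(F)F)ccc2ccccc12)c1cccc(Cl)c1`: in this assay compound 3 gives 98 nM

Compound 3 has the lowest number of the three. The steps of a 44-fold lower number from compound 1 to compound 3 (1.65 log units; beyond the scatter) and a 2.8-fold lower number from compound 2 to compound 3 (0.45 log units; beyond the scatter) are both beyond the scatter, so compound 3 stands apart as the most potent of the measured set; the step of a 16-fold lower number from compound 1 to compound 2 (1.20 log units; beyond the scatter) shows that compound 2 is also well ahead of compound 1.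

Compound 4 `O=C(Nc1c(C(O)(C(F)(F)F)C(F)(F)F)ccc2ccccc12)c1ccc(Br)cc1` is not yet measured. The change from compound 3 is 4-bromophenyl in place of 3-chlorophenyl on a carbonyl carbon. Among the compounds with values here, none of the measured steps moves a halogen on an aromatic ring or exchanges chlorine for bromine; the steps from compound 1 and compound 2 concern the whole group on the carbonyl carbon and do not bear on this smaller change. With no directly relevant comparison, no step beyond the scatter is expected in this assay in either direction. Compound 4 is therefore estimated at 150 nM, with a range of 50 nM to 450 nM. The expected step is a 1.5-fold higher number from compound 3 to compound 4 (0.18 log units; within the scatter).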

Compound 4, half-maximal effective concentration: 47 nM
Compound 4: middle estimate off by 3.2-fold (0.50 log units), on the high side; measured number outside the range, below it.
By their numbers in this assay, from the lowest: compound 4; then compound 3; then compound 2; then compound 1.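

In this assay, the group on this carbonyl carbon still matters among halogenated phenyl groups: a 2.1-fold lower number from compound 3 to compound 4 (0.32 log units; beyond the scatter) is a step beyond the scatter, although the two groups have the same heavy-atom count and the same ring. The 4-bromophenyl group also gives a 5.9-fold lower number from compound 2 to compound 4 (0.77 log units; beyond the scatter) and a 92-fold lower number from compound 1 to compound 4 (1.97 log units; beyond the scatter) as well, which leaves compound 4 with the lowest number of the four and with every step to the others beyond the scatter. Nothing available explains this step.

The swap changes both the halogen and its place on the ring, so the two contributions cannot be separated here; 4-chlorophenyl or 3-bromophenyl on the same carbonyl carbon would separate them. Also open, as far as these compounds go, is whether 4-iodophenyl or 4-methoxyphenyl would continue or reverse this step.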